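The compounds below may be only part of what the source reports. "The series", "measured", "known", "first", "only" and "open" are said of these compounds alone.

Compound 1, `CC(C)[C@@H]1CC[C@@H](C)C[C@@]12N(C)C(=O)[C@@H]1[C@H]3C(=O)NC(=O)[C@H]3ON12`, gives 39.3% in a functional assay, with a stated time of 20 min, tested at 1 mg/mL; on this read-out lower numbers stand for a weaker effect and higher numbers for a stronger effect at the one concentration tested.
Compound 2, `CC(C)[C@@H]1CC[C@@H](C)C[C@@]12N(C)C(=O)[C@@H]1[C@H]3C(=O)N(C)C(=O)[C@H]3ON12`, gives 43.1% in this assay.
Compound 3, `CC(C)[C@@H]1CC[C@@H](C)C[C@@]12N(C)C(=O)[C@@H]1[C@H]3C(=O)N(c4ccccc4)C(=O)[C@H]3ON12`, gives 54.9% in this assay.

All three compounds share one core and differ only in the group carried on an amide-type nitrogen in a ring. Compound 3, which carries a phenyl there, stands highest of the three numbers: its lead over the two smaller groups is shown by a number 15.6 percentage points higher from compound 1 to compound 3 (beyond the scatter) and by a number 11.8 percentage points higher from compound 2 to compound 3 (beyond the scatter), both beyond the scatter, whereas a number 3.8 percentage points higher from compound 1 to compound 2 (within the scatter) stays within it.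

Compound 4, `CC(C)[C@@H]1CC[C@@H](C)C[C@@]12N(C)C(=O)[C@@H]1[C@H]3C(=O)N(c4ccc(Cl)cc4)C(=O)[C@H]3ON12`, keeps the phenyl of compound 3 and adds one change: chloro in place of hydrogen on an aromatic carbon. Within the data shown here, none of the measured steps touches the phenyl itself; each of them swaps the whole group on the nitrogen, so none bears directly on this change. What the numbers do show is that the phenyl-bearing compound 3 sits at the top, and compound 4 retains that phenyl. Among the measured compounds shown here, with no step of this kind measured, the sensible expectation for this assay is a step that stays within the scatter, with no direction that can be called.

For compound 4 the estimated result in this assay is 57%, expected to fall between 42% and 72%, which corresponds to an expected a number 2.1 percentage points higher from compound 3 to compound 4 (within the scatter).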

Compound 4, a percentage reported as activity, at one concentration (the size of the read-out at that concentration, not a potency): 31.7%
The estimate for compound 4 lay 25.3 percentage points above the measured number; measured number below the stated range.
By their numbers in this assay, from the lowest: compounds 4, 1 and 2 (each within the scatter of the next, the first and the last beyond it); then compound 3.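

In this assay the phenyl on the nitrogen proves sensitive to one small addition: chloro in place of hydrogen at the carbon para to a large group gives a number 23.2 percentage points lower from compound 3 to compound 4 (beyond the scatter) and removes the lead that compound 3 held, so having a phenyl at this nitrogen does not by itself secure the higher number. The 4-chlorophenyl group also loses out to the much smaller methyl, with a number 11.4 percentage points lower from compound 2 to compound 4 (beyond the scatter) as the step, while its comparison with plain hydrogen on the same nitrogen gives a number 7.6 percentage points lower from compound 1 to compound 4 (within the scatter) and so separates neither compound from the other. Nothing available here explains why the chloro has this effect.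

The compounds shown leave open whether this drop belongs to chloro itself or to any group at that carbon, since a fluoro, a methyl or a methoxy there would tell those two readings apart. They also leave open whether a chloro on another carbon of the phenyl would behave the same way.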